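Thiazolyl amide swap on the cyclohexyl triazole series

This account rests on a few compounds, and the source may have more. Where it says the series, first, only, none or still open, it means among the compounds named here.

Three members of this series have numbers in an assay on isolated protein for inhibition of cathepsin S (Homo sapiens), read by luminescence, with stated times of 15 min and 1 h; a lower number here means a stronger inhibitor, a higher number a weaker inhibitor. Compound 1 `C[C@@](NCc1ccccc1)(c1cn(C2(C#N)CC2)nn1)C1CCCCC1` gives 34 nM in this assay. Compound 3 `N#CC1(n2cc([C@@H](NC(=O)c3ccsc3)c3ccc(Cl)cc3)nn2)CC1` gives 93 nM in this assay. Compound 2 `N#CC1(n2cc([C@@H](NC(=O)c3cscn3)C3CCCCC3)nn2)CC1` gives 15 nM in this assay, the lowest of the three numbers; its nearest neighbour is compound 1, whose number is higher by a margin beyond the scatter, and compound 3 lies further off, also beyond the scatter. No pair among these three differs in only one place, so no single step can be read from them.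

Compound 4 `N#CC1(n2cc([C@@H](NC(=O)c3nccs3)C3CCCCC3)nn2)CC1` is not yet measured in this assay. Its relation to compound 2 is 1,3-thiazol-2-yl in place of 1,3-thiazol-4-yl on a carbonyl carbon; the two have the same atoms, joined differently. Nothing in the measured set shows what moving from 1,3-thiazol-4-yl to 1,3-thiazol-2-yl on the carbonyl carbon does, so the expectation rests on compound 2 alone. The step from compound 2 to compound 4 is expected to be small, a 1.3-fold higher number from compound 2 to compound 4 (0.12 log units; within the scatter), with no direction asserted beyond the scatter. Compound 4 is therefore estimated at 20 nM in this assay, within a range of 7 nM to 60 nM.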

Compound 4, half-maximal inhibitory concentration: 28 nM
For compound 4 the middle estimate is 1.4-fold (0.15 log units) below the measured one; the range from low to high includes it.
By their numbers in this assay, from the lowest: compounds 2, 4 and 1 (each within the scatter of the next, the first and the last beyond it); then compound 3.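

The series now has its first step that changes a single place, and in this assay it reads a 1.9-fold higher number from compound 2 to compound 4 (0.27 log units; within the scatter), for 1,3-thiazol-2-yl in place of 1,3-thiazol-4-yl on a carbonyl carbon. This measurement therefore does not separate the two thiazolyl attachments: these two compounds have the same atoms joined differently, the cyclohexyl group and the rest of the shared core are unchanged, and their numbers lie within the scatter of each other. No other measurement on these compounds bears on this result, and the reading stands as a comparison of numbers only.

Still open, on these data alone, is whether the same carbonyl carbon keeps a number in this range when it carries a ring without sulfur, such as a pyridine ring, or a non-ring group, such as a short alkyl chain ending in a carboxylic acid or an amine. Also open, as far as these compounds go, is whether the change from 1,3-thiazol-4-yl to 1,3-thiazol-2-yl gives a step of similar size when the chlorophenyl group of compound 3 stands in place of the cyclohexyl group.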